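Working notes: a further methoxy on compound 3

This account rests on a few compounds, and the source may have more. Where it says the series, first, only, none or still open, it means among the compounds named here.

Measured so far:
compound 1 `C/C(=N\O)c1ccc(NC(=O)CSc2nnc(-c3ccccc3)n2-c2ccccc2)cc1`: 50%
compound 2 `COc1ccc(-c2nnc(SCC(=O)Nc3ccc(/C(C)=N/O)cc3)n2-c2ccccc2)cc1`: 45%
compound 3 `CCn1c(SCC(=O)Nc2ccc(C(C)=O)cc2)nnc1-c1ccc(OC)c(OC)c1`: 56%

In a functional assay on the whole organism (strain albino) for inhibition, with Rattus norvegicus as the target, read by paw edema, with stated times of 30 min and 1 h, at a dose of 0.28 mmol/kg by the oral route (a lower number here means less inhibition, a higher number more inhibition at the dose given (going by the name of the read-out)), compound 1 gives 50% and compound 2 gives 45%; the change between them is methoxy in place of hydrogen on an aromatic carbon and it made a number 5 percentage points lower from compound 1 to compound 2 (within the scatter). In this assay compound 3 gives 56%; the difference between the core of compound 3 and the core of compound 1 is not broken down here.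

Compound 4 `CCn1c(SCC(=O)Nc2ccc(C(C)=O)cc2)nnc1-c1cc(OC)c(OC)c(OC)c1` is not yet measured. It differs from compound 3 by methoxy in place of hydrogen on an aromatic carbon. This is the same kind of change as from compound 1 to compound 2, not the same: there the entering methoxy sat para to a large group, here it sits ortho to a methoxy group, meta to a large group and meta to a methoxy group.

The step from compound 3 to compound 4 is estimated as a number 4 percentage points lower from compound 3 to compound 4 (within the scatter) because the earlier step of this kind gave a number 5 percentage points lower from compound 1 to compound 2 (within the scatter). Compound 4 is expected to give about 52% in this assay. For compound 4 the expected range runs from 40% to 64%.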

Compound 4, a percentage reported as inhibition, in the whole organism at one dose (the size of the read-out at that dose, not a potency): 46%
Estimate against measurement, compound 4: 6 percentage points above; low and high end bracket the measured number.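

In this assay the new step is a number 10 percentage points lower from compound 3 to compound 4 (within the scatter) and so gives no clear change on this core. Set beside the earlier step, the methoxy change shows no difference between the two cores: the same change on two cores in this assay, a number 5 percentage points lower (within the scatter) from compound 1 to compound 2 and a number 10 percentage points lower (within the scatter) from compound 3 to compound 4, 5 percentage points apart, within the scatter of two such steps. This agreement rests on two pairs at one dose, with the methoxy entering at different places, and it does not show that methoxy has a real effect on either core, as neither step lies beyond the scatter.

Open, on these data alone, is whether another group at the same place, such as an amine, a carboxylic acid or ethoxy, would move the read-out beyond the scatter. Also open, as far as these compounds go, is whether a third core would give a similar methoxy step.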